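The source may report more compounds than this note shows. Statements on the series, on what has been measured and on what is new or still open speak of the compounds shown alone.

In a functional assay on HCT-116 cells (Homo sapiens) for antiproliferative activity, read by MTT assay, with a stated time of 48 h (a higher number here means a weaker inhibitor, a lower number a stronger inhibitor), compound 1 (`O=C(NO)c1cn(C2CC2)c2cc(-n3cc(CN4CCCCC4)nn3)c(F)cc2c1=O`) gives > 10000 nM as a limit, not a number. Compound 2 (`CCCN(CCC)Cc1cn(-c2cc3c(cc2F)c(=O)c(C(=O)NO)cn3C2CC2)nn1`) gives > 10000 nM and this too is only a limit. For the measured compounds named here, the one measured change (a step that the two limits leave unreadable from compound 1 to compound 2) offers no size to carry forward, and the evidence so far is just the limit of > 10000 nM in this assay, at which 2 of the 2 values shown sit, and nothing finer. Compound 3 (`CN(C)Cc1cn(-c2cc3c(cc2F)c(=O)c(C(=O)NO)cn3C2CC2)nn1`) carries dimethylamino in place of dipropylamino on a saturated chain carbon bound to an aromatic carbon. No step beyond the scatter, in either direction, is expected in this assay and the estimated step stays small (a step that the limit leaves unreadable from compound 2 to compound 3). For compound 3 the expected value is 15000 nM with an estimated range from 4000 nM to 50000 nM overall.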

Compound 3, half-maximal inhibitory concentration: > 10000 nM
Compound 3 ended at the assay's limit; the forecaster's own chance of this, stated with the estimate: 75%; the middle value lies beyond the limit too.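

No step can be read among compound 1, compound 2 and compound 3, since each result is only a limit, not a number: the limit of > 10000 nM in this assay, at which 3 of the 3 values shown sit. The compounds shown leave open how strongly each acts in this assay and whether swapping the amino group changes that at all.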